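The compounds below may be only part of what the source reports. "The series", "measured", "known", "first", "only" and "open" are said of these compounds alone.

In a functional assay on HCT-116 cells (Homo sapiens) for antiproliferative activity, read by MTT assay, with a stated time of 48 h (on this read-out lower numbers stand for stronger inhibition and higher numbers for weaker inhibition), compound 3 `COc1ccccc1-n1nncc1CN1C(=O)C2(C(C#N)=C(N)Oc3c2c2nc4ccccc4nc2c2ccccc32)c2ccccc21` gives > 50000 nM, a limit of the assay rather than a number. Compound 1 `Cc1ccccc1-n1nncc1CN1C(=O)C2(C(C#N)=C(N)Oc3c2c2nc4ccccc4nc2c2ccccc32)c2ccccc21` gives > 50000 nM in this assay, again a limit. Compound 2 `N#CC1=C(N)Oc2c(c3nc4ccccc4nc3c3ccccc23)C12C(=O)N(Cc1cnnn1-c1ccccc1Br)c1ccccc12` gives > 50000 nM, also a limit. All three compounds share the same core and differ only in the substituent on the phenyl ring attached to the triazole nitrogen, and because the limit of > 50000 nM in this assay, at which 3 of the 3 values shown sit, none of the three steps among them can be read: the step that the two limits leave unreadable from compound 1 to compound 2, the step that the two limits leave unreadable from compound 1 to compound 3 and the step that the two limits leave unreadable from compound 2 to compound 3 all remain of unknown size.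

Compound 4 `N#CC1=C(N)Oc2c(c3nc4ccccc4nc3c3ccccc23)C12C(=O)N(Cc1cnnn1-c1ccc(N)cc1)c1ccccc12` carries 4-aminophenyl in place of 2-methoxyphenyl on an aromatic nitrogen. Among the compounds with values here, the measured steps that bear on this change are the three just named, and each of them is unreadable, so they offer no direction for what to expect in this assay; the only guidance is that every variation of this phenyl ring so far has left the value at the limit. Within the data shown here, an amino group is a different kind of substituent from methyl, bromo or methoxy, but no measured step shows what it does here.

Compound 4 is therefore expected to give 60000 nM, with a plausible range from 15000 nM to 250000 nM. This estimate corresponds to a step that the limit leaves unreadable from compound 3 to compound 4, most likely again reported only as a limit.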

Compound 4, half-maximal inhibitory concentration: 45200 nM
Compound 4: the middle estimate sits 1.3-fold (0.12 log units) above what was measured, within the range that was stated.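

In this assay compound 4 gives 45200 nM, the only value among the aryl groups shown on this ring nitrogen that is a number rather than a limit. That number does not establish a gain: the result is an at least 1.1-fold lower number from compound 3 to compound 4 (0.04 log units; that floor lies within the scatter), an at least 1.1-fold lower number from compound 2 to compound 4 (0.04 log units; that floor lies within the scatter) and an at least 1.1-fold lower number from compound 1 to compound 4 (0.04 log units; that floor lies within the scatter), so each of these steps is only a floor, and each floor lies within the scatter. The true size of the steps stays unknown, and 4-aminophenyl cannot be ranked against 2-methoxyphenyl, 2-bromophenyl or 2-methylphenyl, because the other three compounds sit at a limit: the limit of > 50000 nM in this assay, at which 3 of the 4 values shown sit.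

The names 4-aminophenyl and 2-methoxyphenyl differ both in the group and in where it stands on the phenyl ring, and the compounds shown do not separate these two changes. Also open, going by these compounds, is whether a carboxylic acid or a longer chain on this phenyl ring would give a value that can be compared with that of compound 4.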